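The compounds below may be only part of what the source reports. "The series", "measured", "known", "first", "only" and "open" are said of these compounds alone.

Going by the values given here, in an ADME assay on cells (Hepatocyte, Mus musculus) for cytotoxicity, read by MTT assay, with a stated time of 24 h (on this read-out higher numbers stand for lower toxicity in this test and lower numbers for higher toxicity in this test), compound 1 `Cc1ccc(-c2nn(-c3ccccc3)cc2-c2nc3ccccc3n2S(=O)(=O)c2ccccc2)cc1` gives 189000 nM and compound 2 `O=S(=O)(c1ccccc1)n1c(-c2cn(-c3ccccc3)nc2-c2ccc(C(F)(F)F)cc2)nc2ccccc21` gives 186000 nM, so compound 2 stands level with its only neighbour. Compound 3 `O=S(=O)(c1ccc(F)cc1)n1c(-c2cn(-c3ccccc3)nc2-c2ccc(C(F)(F)F)cc2)nc2ccccc21` differs from compound 2 in one place, where phenylsulfonyl becomes (4-fluorophenyl)sulfonyl: fluoro in place of hydrogen on an aromatic carbon. Among the compounds with values here, the single measured step, a 1.0-fold lower number from compound 1 to compound 2 (0.01 log units; within the scatter), swaps methyl for trifluoromethyl elsewhere in the molecule and stays within the scatter. Within the data shown here, no measured step tests fluoro in place of hydrogen, so this is weak guidance, and no change beyond the scatter is expected in this assay. The expected step is a 1.0-fold lower number from compound 2 to compound 3 (0.01 log units; within the scatter). For compound 3 the estimated value is 180000 nM, with a range of 105000 nM to 300000 nM.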

Compound 3, half-maximal cytotoxic concentration: 83300 nM
The estimate for compound 3 lay 2.2-fold (0.33 log units) above the measured number; the measured number lies below the stated range.
By their numbers in this assay, from the lowest: compound 3; then compounds 2 and 1 (each within the scatter of the next).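

In this assay the phenyl on the sulfonyl group proves responsive to change: fluoro in place of hydrogen gives a 2.2-fold lower number from compound 2 to compound 3 (0.35 log units; beyond the scatter), which here means higher toxicity in this test. Thus, one added heavy atom at this site moves the number beyond the scatter, whereas the swap elsewhere in the molecule, a 1.0-fold lower number from compound 1 to compound 2 (0.01 log units; within the scatter), did not. Nothing measured here explains the drop. Still open, as far as these compounds go, is whether chloro, methoxy or an amine at this site would shift the number similarly, and whether fluoro would have the same effect with methyl in place of trifluoromethyl.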